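Methyl in place of chloro: cytotoxicity expected to stay unchanged

This account rests on a few compounds, and the source may have more. Where it says the series, first, only, none or still open, it means among the compounds named here.

Measured so far:
compound 1 `O=C(Nc1cc(-c2nc3ccccc3s2)ccc1Cl)c1cc([N+](=O)[O-])ccc1Cl` — in an ADME assay on HEK293 cells (Homo sapiens) for cytotoxicity, with a stated time of 72 h (on this read-out lower numbers stand for an effect already at smaller amounts and higher numbers for an effect only at larger amounts of compound), compound 1 gives > 25000 nM
compound 2 `O=C(Nc1ccc(O)c(-c2nc3ccccc3s2)c1)c1cc([N+](=O)[O-])ccc1Cl` — in this assay compound 2 gives > 25000 nM

The value for compound 1 is a limit of the assay, not a number. The same holds for compound 2. For the measured compounds named here, compound 1 therefore stands at the limit of > 25000 nM in this assay, at which 2 of the 2 values shown sit, so no cytotoxic effect was seen for it within the tested range, and no step between measured compounds can be read from these two results.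

The next compound, compound 3 `Cc1ccc(-c2nc3ccccc3s2)cc1NC(=O)c1cc([N+](=O)[O-])ccc1Cl`, differs from compound 1 in one place: methyl in place of chloro on an aromatic carbon. Going by the values given here, nothing among the measured compounds links this change to a shift in this assay, and with compound 1 sitting at the limit, the step from compound 1 to compound 3 is expected to show no effect beyond the usual scatter, which means an estimated step that the limit leaves unreadable from compound 1 to compound 3. Compound 3 is thus expected to give about 30000 nM, somewhere between 10000 nM and 100000 nM, most likely again as a limit rather than a number.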

Compound 3, half-maximal effective concentration: > 14000 nM
Compound 3: only a limit was reported (the forecaster's own chance of this, stated with the estimate: 80%); the middle value is on the limit's open side.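

Compound 1 and compound 3 each gave only a limit in this assay, not a number, so no step can be read for methyl in place of chloro. These compounds leave open at what concentration, if any, either one would show cytotoxicity.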